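The source may report more compounds than this note shows. Statements on the series, on what has been measured and on what is new or still open speak of the compounds shown alone.

Compound 1 `COc1ccc2cc([C@H](C)c3nnc(SCc4ccc(C)cc4)n3-c3ccc(F)cc3)ccc2c1`: 44300 nM
Compound 2 `COc1ccc2cc([C@H](C)c3nnc(SCc4ccccc4)n3-c3ccc(Cl)cc3)ccc2c1`: 35800 nM

Both compounds were tested in a functional assay on DU-145 cells (Homo sapiens) for cytotoxicity, read by MTT assay; a higher number here means a weaker inhibitor, a lower number a stronger inhibitor. Compound 1 stands level with compound 2, as the gap between their two values lies within the scatter. Compound 3 `COc1ccc2cc([C@H](C)c3nnc(SCc4ccc(F)cc4)n3-c3ccc(F)cc3)ccc2c1` keeps the core of compound 1 and has fluoro in place of methyl on an aromatic carbon, para to a large group, turning the 4-methylbenzyl into 4-fluorobenzyl: fluoro in place of methyl on an aromatic carbon. For the measured compounds named here, no measured pair shows this change alone, since compound 2 differs from compound 1 in more than one place. The two values give only a narrow window in this assay, and no step beyond the scatter is expected, in either direction. The expected 1.1-fold lower number from compound 1 to compound 3 (0.04 log units; within the scatter) is small. For compound 3 the estimated value is 40000 nM, with an expected range from 20000 nM to 80000 nM.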

Compound 3, half-maximal inhibitory concentration: 60200 nM
For compound 3 the middle estimate is 1.5-fold (0.18 log units) below the measured one, within the range that was stated.
By their numbers in this assay, from the lowest: compounds 2, 1 and 3 (each within the scatter of the next).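

For the compounds shown here, compound 3 provides the only single-place comparison here: in this assay replacing 4-methylbenzyl with 4-fluorobenzyl on the sulfanyl group gives a 1.4-fold higher number from compound 1 to compound 3 (0.13 log units; within the scatter), which stands within the scatter. At this position, para to a large group, fluoro and methyl therefore cannot be told apart in this assay, and compound 1 and compound 3 stand level. Nothing measured here bears on why the two groups read alike.

The compounds shown leave open whether a group of a different kind at the same place, such as an amine or a carboxylic acid, would shift the number beyond the scatter. They also leave open whether the same exchange would read alike on a core other than that of compound 1.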